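Trading a Dienyl Amide for a Cyclopropyl Amide

The compounds below may be only part of what the source reports. "The series", "measured", "known", "first", "only" and "open" are said of these compounds alone.

Within the data shown here, compound 1 `C/C=C/C=C/C(=O)N(Cc1ccc(OC)c(O)c1)c1cc(OC)c(OC)c(OC)c1` gives 180 nM in a functional assay on HCT-116 cells (Homo sapiens) for inhibition, read by MTT assay, with a stated time of 48 h (on this read-out higher numbers stand for weaker inhibition and lower numbers for stronger inhibition), the lowest of the three numbers measured so far. Compound 3 `C/C=C/C(=O)N(Cc1ccc(OC)c(Cl)c1)c1cc(OC)c(OC)c(OC)c1` gives 1420 nM in this assay, beyond the scatter above compound 1, and compound 2 `COc1ccc(CNc2cc(OC)c(OC)c(OC)c2)cc1C`, which has no carbonyl group at all, gives 60900 nM, far beyond it. Compound 4 `COc1ccc(CN(C(=O)C2CC2)c2cc(OC)c(OC)c(OC)c2)cc1O` is not yet measured; it differs from compound 1 by cyclopropyl in place of penta-1,3-dien-1-yl on a carbonyl carbon. Among the measured compounds shown here, no measured pair shows this exact change. Both measured neighbours of compound 1 sit higher, so a moderate loss is expected, with the step of a 3.9-fold higher number from compound 1 to compound 4 (0.59 log units; beyond the scatter) in this assay. Compound 4 is estimated at 700 nM, within 200 nM to 3000 nM.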

Compound 4, half-maximal inhibitory concentration: 49 nM
Compound 4: middle estimate off by 14-fold (1.15 log units), on the high side, and the stated range ends above it.
By their numbers in this assay, from the lowest: compound 4; then compound 1; then compound 3; then compound 2.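

On this carbonyl carbon, the penta-1,3-dien-1-yl chain is not required for activity: replacing it with cyclopropyl gives a 3.7-fold lower number from compound 1 to compound 4 (0.57 log units; beyond the scatter) in this assay. A chain with two double bonds can therefore give way to a three-membered carbon ring with fewer heavy atoms, and the number still falls modestly. Nothing available here explains why this change lowers the number.

The compounds shown leave open how a cyclobutyl ring, a plain methyl group or a tert-butyl group would behave on the same carbonyl carbon. They also leave open whether a cyclopropyl ring bearing a fluorine would keep this result.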